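The source may report more compounds than this note shows. Statements on the series, on what has been measured and on what is new or still open speak of the compounds shown alone.

Compound 1 `Fc1ccc(CSc2nnc(-c3ccncc3)n2-c2ccccc2)c(F)c1` gives 11400 nM in a functional assay on HCT-116 cells (Homo sapiens) for inhibition, read by MTT assay, with a stated time of 48 h; a higher number here means a weaker inhibitor, a lower number a stronger inhibitor. Compound 2 `O=[N+]([O-])c1ccccc1CSc1nnc(-c2ccncc2)n1-c1ccccc1` gives only a limit there, > 50000 nM. Compound 3 `O=C(CSc1nnc(-c2ccncc2)n1-c1ccccc1)N/N=C/c1ccc(O)cc1` gives only a limit as well, > 50000 nM.

Compound 3 therefore stands at the limit of > 50000 nM in this assay, at which 2 of the 3 values shown sit, with no number of its own. Compound 4 `O=C(CSc1nnc(-c2ccncc2)n1-c1ccccc1)N/N=C/c1cc(Br)cc(Br)c1O` differs from compound 3 by 3,5-dibromo-2-hydroxyphenyl in place of 4-hydroxyphenyl on a carbon with a double bond to nitrogen. For the measured compounds named here, the single measured step, an at least 4.3-fold higher number from compound 1 to compound 2 (0.64 log units; beyond the scatter), varies the ring on the chain carbon bound to sulfur, a different place on the shared core, so no measured step bears on the present change, and no measured pair varies the ring on the carbon with a double bond to nitrogen. Since compound 3 sits at the limit, a step to a higher number could not be seen at all. Compound 4 is expected to give 35000 nM, within 8000 nM to 100000 nM. The expected step is thus an at least 1.4-fold lower number from compound 3 to compound 4 (0.15 log units; that floor lies within the scatter), and a further limit remains quite possible.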

Compound 4, half-maximal inhibitory concentration: 4500 nM
Estimate against measurement, compound 4: 7.8-fold (0.89 log units) above; measured number below the stated range.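

The ring on the carbon with a double bond to nitrogen now has a measured step in this assay: 3,5-dibromo-2-hydroxyphenyl in place of 4-hydroxyphenyl gives an at least 11-fold lower number from compound 3 to compound 4 (1.04 log units; beyond the scatter). This position therefore responds to its ring, as does the ring on the chain carbon bound to a sulfur in an at least 4.3-fold higher number from compound 1 to compound 2 (0.64 log units; beyond the scatter). The size of the new step is only a floor, since compound 3 stands at a limit: the limit of > 50000 nM in this assay, at which 2 of the 4 values shown sit.

The compounds shown do not separate the share of the bromine atoms from that of the hydroxy placement. From the compounds shown here alone, how an amine or a carboxylic acid on this ring would read remains open.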